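Series notes: ring-nitrogen substituent, compound 3 to compound 4

A few compounds are considered here, and "the series" means these few. Any claim that something is new, unique, unknown or untested is made for them only; others in the source may bear on it.

Measured so far in an assay on HEK293 cells for positive allosteric modulation of metabotropic glutamate receptor 5 (Homo sapiens), read by FLIPR, with a stated time of 1 h; a lower number here means that less compound is needed, a higher number that more compound is needed for the effect:
compound 1 `Cc1cccc(C#Cc2nc3c(s2)C(=O)NCC3)c1` gives > 10000 nM, a limit of the assay.
compound 2 `Fc1cccc(C#Cc2nc3c(s2)CN(C2CCC2)CC3)c1` gives > 10000 nM, a limit of the assay.
compound 3 `C(#Cc1nc2c(s1)CN(C1CCCCC1)CC2)c1ccccc1` gives > 10000 nM, a limit of the assay.

None of the three measured compounds has a numerical half-maximal effective concentration; each value is a limit and not a number. For the measured compounds named here, compound 3 therefore stands at the limit of > 10000 nM in this assay, at which 3 of the 3 values shown sit, so its position relative to the other two cannot be ordered, and no step between measured compounds can be given.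

The next compound, compound 4 `O=C(C1CC(F)C1)N1CCc2nc(C#Cc3ccccc3)sc2C1`, differs from compound 3 in one place: (3-fluorocyclobutyl)carbonyl in place of cyclohexyl on an amine nitrogen in a ring. In words, (3-fluorocyclobutyl)carbonyl takes the place of cyclohexyl on an amine nitrogen in a ring.

With no measured step in this assay and only limits on record, there is nothing in the shown values that points to a direction for this change. The expectation is therefore held loosely: a downward movement is considered possible, but a value still at the limit is also expected to be likely. Compound 4 is estimated at 3000 nM, within 300 nM to 20000 nM. This corresponds to an expected step of an at least 3.3-fold lower number from compound 3 to compound 4 (0.52 log units; beyond the scatter), which should be read against the fact that compound 3 carries only a limit.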

Compound 4, half-maximal effective concentration: 85 nM
Beside the measured number, compound 4's estimate is 35-fold (1.55 log units) above it, outside the stated range (below it).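

On the amine nitrogen in a ring, (3-fluorocyclobutyl)carbonyl in place of cyclohexyl yields the first numerical half-maximal effective concentration of the series in this assay, with an at least 110-fold lower number from compound 3 to compound 4 (2.07 log units; beyond the scatter). The earlier compounds shown here, which offered only limits, could not show that this position can carry the series from the limit of the assay to a measured value, or that a step of this size is possible through a single exchange there. The size of this step is only a bound, because the value of compound 3 is a limit of the assay and not a number: the limit of > 10000 nM in this assay, at which 3 of the 4 values shown sit.

The exchange alters three things at once, as the ring goes from six-membered to four-membered, a carbonyl enters and a fluorine enters, so the compounds shown do not say which of these accounts for the step. A cyclohexylcarbonyl group or an unfluorinated cyclobutylcarbonyl group on the same nitrogen would separate these contributions, and a methanesulfonyl group would test whether the carbonyl itself can be replaced.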